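The source may hold more compounds than are shown below. What is called first, only, known or untested is meant among the compounds shown, and "the series" means these compounds.

Measured so far in an ADME assay on microsomes from liver (Rattus norvegicus) for metabolic stability, with a stated time of 10 min; on this read-out higher numbers stand for a more stable compound and lower numbers for a less stable compound:
Compound 1 `FC(F)(F)c1ccccc1-c1cc(Cl)c2[nH]c(C3=NOC4(CCCCC4)C3)nc2c1`: 100%
Compound 2 `Fc1ccccc1-c1cc(C(F)(F)F)c2[nH]c(C3=NOC4(CCCCC4)C3)nc2c1`: 100%

Compound 1 gives 100%, level with compound 2 at 100%, so neither compound shows any measurable loss in this test. Compound 3 `OCCCc1cc(-c2ccccc2C(F)(F)F)cc2nc(C3=NOC4(CCCCC4)C3)[nH]c12` keeps the core and the 2-(trifluoromethyl)phenyl group of compound 1 and changes in one place: 3-hydroxypropyl in place of chloro on an aromatic carbon. In words, a 3-hydroxypropyl takes the place of chloro on an aromatic carbon.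

Going by the values given here, the two measured compounds differ from each other in more than one place, so no measured pair shows what a single change does here. Nothing yet measured covers a 3-hydroxypropyl group, which leaves the size of this step poorly defined. Compound 1 already reads 100%, so on a read-out of compound remaining it has no room to rise, and any real change would appear as a fall. The expected change in this assay is a fall beyond the usual scatter, estimated as a number 25 percentage points lower from compound 1 to compound 3 (beyond the scatter). Compound 3 is expected to read 75%, with an estimated range from 45% to 98%.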

Compound 3, percent of the compound remaining: 74%
Beside the measured number, compound 3's estimate is 1 percentage points above it; low and high end bracket the measured number.
By their numbers in this assay, from the lowest: compound 3; then compounds 1 and 2 (each within the scatter of the next).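

In this assay, going by these compounds alone, putting a 3-hydroxypropyl in place of chloro gives a number 26 percentage points lower from compound 1 to compound 3 (beyond the scatter), the first change at a single place that can be read. It shows that this aromatic carbon, ortho to a fused ring and meta to a 2-(trifluoromethyl)phenyl group, is not indifferent to what it carries, although compound 3 still gives 74%, so the fall is modest and much of the compound remains at the stated time. The data offer no measured basis for saying which feature of the incoming chain lies behind this fall.

The compounds shown leave open whether the fall goes with the chain itself or with the hydroxyl at its end, a question that a plain propyl group would help to settle, while a shorter 2-hydroxyethyl chain or a longer 4-hydroxybutyl chain would show how the result follows chain length. They also leave open how an amine or a carboxylic acid at the end of the chain would read, and whether the same change would have a similar effect with the 2-fluorophenyl group of compound 2 in place of the 2-(trifluoromethyl)phenyl group.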